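This account rests on a few compounds, and the source may have more. Where it says the series, first, only, none or still open, it means among the compounds named here.

The three measured compounds:

Compound 1, `CCC(CCOC)n1c(OC)nc2c(-c3ccc(OC(F)(F)F)cc3Cl)ccnc21`, gives 1.9 nM in an assay for binding affinity to Corticotropin releasing factor receptor (Rattus norvegicus); on this read-out lower numbers stand for stronger inhibition and higher numbers for weaker inhibition.
Compound 2, `CCCC(C)n1c(CC)nc2c(-c3cc(C)c(OC)cc3C)ccnc21`, gives 0.6 nM in this assay.
Compound 3, `CCCC(C)n1c(CC)nc2c(-c3ccc(Cl)cc3C(C)=O)ccnc21`, gives 95.6 nM in this assay.

Compound 3 thus stands at the highest number of the three, that is, it binds the weakest of the set. Its nearest neighbour is compound 1, and even that lies far lower, beyond the usual scatter; compound 2 lies lower still, also well beyond the scatter.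

Compound 4, `CCCC(C)n1c(CC)nc2c(-c3ccc(Cl)cc3Cl)ccnc21`, has not yet been measured. It differs from compound 3 in one spot only: chloro in place of acetyl on an aromatic carbon. Everything else, including the shared core and its side chains, is the same as in compound 3. Among the compounds with values here, no measured pair shows this exact exchange, so the size of the step can only be inferred from the spread of the three values. Compounds 1 and 2, which carry no acetyl group on their aryl ring, both sit at low numbers, whereas compound 3, which carries one, sits at a high number. Removing the acetyl group and putting a chloro group in its place is therefore expected to bring the number down considerably. This expectation corresponds to a step of a 38-fold lower number from compound 3 to compound 4 (1.58 log units; beyond the scatter). Compound 4 is expected to give about 2.5 nM in this assay, with a likely range from 0.5 nM to 12 nM.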

Compound 4, inhibition constant: 0.5 nM
The estimate for compound 4 lay 5.0-fold (0.70 log units) above the measured number, within the range that was stated.
By their numbers in this assay, from the lowest: compounds 4 and 2 (each within the scatter of the next); then compound 1; then compound 3.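

In this assay, putting chloro in place of acetyl on this aromatic carbon, with the rest of the molecule unchanged, gives a 190-fold lower number from compound 3 to compound 4 (2.28 log units; beyond the scatter), a large step beyond the scatter. The earlier compounds shown here could not show this: compound 3 differs from compound 1 and compound 2 in more than one place, so its high number could not be tied to any single part of the structure, whereas this matched pair ties a gap of this size to one group at one position, on a ring carbon ortho to a large group. The data give no explanation of why acetyl and chloro differ so much here.

On these data alone, what remains open is which feature of the acetyl group goes with the weaker binding, its carbonyl or simply its three heavy atoms in place of one, and an ethyl group, which has no carbonyl, or a nitrile or a methoxy group at the same carbon would help to separate these. As far as these compounds go, it also remains open whether an amine or a carboxylic acid would be tolerated at this position, and whether the same exchange gives a step of similar size with other groups elsewhere on the ring or on the shared core.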